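Adding a Second Chloro to the Aryl Ring of Compound 3

A few compounds are considered here, and "the series" means these few. Any claim that something is new, unique, unknown or untested is made for them only; others in the source may bear on it.

Measured so far in a functional assay on HCT-116 cells (Homo sapiens) for inhibition, read by sulforhodamine B assay, with a stated time of 48 h; on this read-out higher numbers stand for weaker inhibition of growth and lower numbers for stronger inhibition of growth:
compound 1 `N#C/C(=C\N1CCN(C(=O)c2ccco2)C1=S)C(=O)Nc1ccc(Cl)cc1` gives 15200 nM
compound 2 `N#C/C(=C\N1CCN(C(=O)c2ccco2)C1=S)C(=O)c1ccccc1` gives 9100 nM
compound 3 `O=CN1CCN(c2ccc(Cl)cc2)C1=S` gives 18000 nM

Compound 3 carries the highest of the three numbers in this assay, yet its distance to compound 1 and to compound 2 stays within the usual scatter, so the three compounds cannot be ordered. For the measured compounds named here, the only single-point step measured, a 1.7-fold lower number from compound 1 to compound 2 (0.22 log units; within the scatter), concerns a different part of the molecule and says nothing about the change now considered. Compound 4 `O=CN1CCN(c2ccc(Cl)c(Cl)c2)C1=S` differs from compound 3 by chloro in place of hydrogen on an aromatic carbon. Going by the values given here, with no comparable step in hand, compound 4 is expected to show a step of a 1.2-fold lower number from compound 3 to compound 4 (0.08 log units; within the scatter), that is, nothing beyond the scatter. Compound 4 is therefore estimated at 15000 nM, with a range from 6000 nM to 40000 nM.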

Compound 4, concentration for 50% growth inhibition: 16200 nM
Beside the measured number, compound 4's estimate is 1.1-fold (0.03 log units) below it; low and high end bracket the measured number.
By their numbers in this assay, from the lowest: compounds 2, 1, 4 and 3 (each within the scatter of the next).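

In this assay chloro in place of hydrogen on an aromatic carbon, ortho to a chloro group and meta to a group of 8 heavy atoms, gives a 1.1-fold lower number from compound 3 to compound 4 (0.05 log units; within the scatter) and so stays within the scatter. This is the first step shown on this ring, and at this position the added chloro leaves growth inhibition without a readable change. No evidence at hand bears on this result.

From the compounds shown here alone, whether an amine or a carboxylic acid at this position would give the same result remains open. So does whether a longer chain there would.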